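The compounds below may be only part of what the source reports. "The series", "measured", "known", "first", "only" and "open" are said of these compounds alone.

Measured in a functional assay on MDA-MB-231 cells (Homo sapiens) for antiproliferative activity, read by MTT assay, with a stated time of 48 h; a lower number here means a stronger inhibitor, a higher number a weaker inhibitor:
- compound 1 `COC(=O)/C(=C/c1ccccc1)CN1C(=O)[C@@H](OC)[C@H]1c1ccc(Cl)cc1`: 15600 nM
- compound 2 `CCOC(=O)/C(=C/c1ccccc1)CN1C(=O)[C@@H](OC)[C@H]1c1ccc(Cl)cc1`: 11100 nM
- compound 3 `COC(=O)/C(=C/c1ccccc1)CN1C(=O)[C@@H](OC)[C@H]1c1ccccc1C(F)(F)F`: 17600 nM

The three values lie within the scatter of one another, so compound 3 at 17600 nM is not separated from compound 1 or compound 2.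

Next in the series is compound 4 `COC(=O)/C(=C/c1ccccc1)CN1C(=O)[C@@H](OC)[C@H]1c1ccc(F)cc1`, with 4-fluorophenyl in place of 2-(trifluoromethyl)phenyl on a saturated ring carbon. For the measured compounds named here, no measured compound carries 4-fluorophenyl. The closest evidence is a 1.1-fold higher number from compound 1 to compound 3 (0.05 log units; within the scatter), where the aryl group on that same carbon changed from 4-chlorophenyl to 2-(trifluoromethyl)phenyl. The other measured step, a 1.4-fold lower number from compound 1 to compound 2 (0.15 log units; within the scatter), lies elsewhere in the molecule and bears on this change only as a sign of how flat the series is so far.

No step beyond the scatter is therefore expected in this assay, and the expected step is a 1.2-fold lower number from compound 3 to compound 4 (0.07 log units; within the scatter). For compound 4 the estimated value is 15000 nM, with an expected range of 8500 nM to 27000 nM.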

Compound 4, half-maximal inhibitory concentration: 21800 nM
Beside the measured number, compound 4's estimate is 1.5-fold (0.16 log units) below it, within the range that was stated.
By their numbers in this assay, from the lowest: compounds 2, 1, 3 and 4 (each within the scatter of the next).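

In this assay, 4-fluorophenyl is a third aryl group on the saturated ring carbon next to the ring nitrogen, and replacing 2-(trifluoromethyl)phenyl with it gives a 1.2-fold higher number from compound 3 to compound 4 (0.09 log units; within the scatter). The series now also has a change of halogen alone, fluoro in place of chloro on an aromatic carbon, which gives a 1.4-fold higher number from compound 1 to compound 4 (0.15 log units; within the scatter), so none of the three aryl groups at this position is separated from another in this assay. No measurement at hand offers an explanation for these steps.

On these data alone, it remains open whether an aryl group carrying an amine or a carboxylic acid at this position would give a step beyond the scatter. A longer chain on the ester oxygen is also untested by the compounds shown here, so the reach of that part of the molecule remains unknown.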